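Notes on compound 4: furan-2-yl in place of phenyl

This account rests on a few compounds, and the source may have more. Where it says the series, first, only, none or still open, it means among the compounds named here.

Three compounds have numbers in a functional assay on HepG2 cells (Homo sapiens) for cytotoxicity, read by MTT assay, with a stated time of 48 h; on this read-out lower numbers stand for stronger inhibition and higher numbers for weaker inhibition. Compound 1 `CCCCCCCCNC(=O)[C@@H](NC(=O)c1ccco1)[C@@H](C)O` gives 192000 nM and compound 2 `CCCCCCCCCCCCNC(=O)[C@@H](NC(=O)c1ccco1)[C@@H](C)O` gives 147000 nM; the step of a 1.3-fold lower number from compound 1 to compound 2 (0.12 log units; within the scatter) is within the scatter. Compound 3 `CCCCCCCCCCCCCCNC(=O)[C@@H](NC(=O)c1ccccc1)[C@@H](C)O` gives 54200 nM and stands lowest of the three, beyond the scatter from both compound 2 and compound 1. Compound 4 `CCCCCCCCCCCCCCNC(=O)[C@@H](NC(=O)c1ccco1)[C@@H](C)O` differs from compound 3 by furan-2-yl in place of phenyl on a carbonyl carbon, the same difference read one bond further out being benzoyl to (furan-2-yl)carbonyl. For the measured compounds named here, no measured step bears directly on this change: compound 2 carries the furan-2-yl group but also a shorter chain, so its value and that of compound 3 show only what two changes together do, and the one measured step, which concerns the chain alone, is within the scatter. Compound 4 is therefore expected to show only a small shift toward a higher number, a 1.4-fold higher number from compound 3 to compound 4 (0.14 log units; within the scatter). For compound 4 the estimate in this assay is 75000 nM, within 30000 nM to 180000 nM.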

Compound 4, half-maximal inhibitory concentration: > 400000 nM
Compound 4 was reported as a limit (the forecaster's own chance of this, stated with the estimate: 5%); middle value at least 5.3-fold (0.72 log units) from the limit.
By their numbers in this assay, from the lowest: compound 3; then compounds 2 and 1 (each within the scatter of the next). At a limit, above all of these: compound 4.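

Compound 4 stands only as a limit, not as a number, in this assay: the limit of > 400000 nM in this assay, at which 1 of the 4 values shown sits.

For the compounds shown here, this gives the first reading of furan-2-yl in place of phenyl on a carbonyl carbon with the chain held fixed, and the change is beyond the scatter: an at least 7.3-fold higher number from compound 3 to compound 4 (0.86 log units; beyond the scatter). With furan-2-yl held, the longest chain does not bring a lower number either, since the steps read an at least 2.7-fold higher number from compound 2 to compound 4 (0.43 log units; beyond the scatter) and an at least 2.0-fold higher number from compound 1 to compound 4 (0.31 log units; beyond the scatter), while the earlier chain step alone, a 1.3-fold lower number from compound 1 to compound 2 (0.12 log units; within the scatter), had stayed within the scatter.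

As far as these compounds go, how far compound 4 lies past its limit remains open, so these steps have only a lower bound. Also open, from the compounds shown here alone, are whether thiophen-2-yl on the same carbonyl carbon reads like phenyl or like furan-2-yl, and whether phenyl keeps its advantage on the chains of compound 1 and compound 2.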